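One Change on the Aromatic Ring of Compound 1

The source may hold more compounds than are shown below. What is called first, only, known or untested is meant among the compounds shown, and "the series" means these compounds.

Measured so far:
compound 1, `Cc1ccc(N2CCN/C2=N\N)cc1`: 12%
compound 2, `Cc1cccc(N2CCn3c2n[nH]c(=O)c3=O)c1C`: 21%

In a functional assay on T47D cells (Homo sapiens) for cytotoxicity, with a stated time of 72 h, tested at 10 ug/mL (a higher number here means a stronger effect of the compound at the concentration tested, a lower number a weaker effect), compound 1 gives 12%, and compound 2 gives 21%. The two numbers lie within the scatter of each other, so neither compound stands apart. Compound 3, `COc1ccc(N2CCN/C2=N\N)cc1`, differs from compound 1 in one place: methoxy in place of methyl on an aromatic carbon. Within the data shown here, no measured pair shows this exchange, so nothing here tells how large its effect is; a small step, if any, is expected, in either direction and not beyond the scatter. The expected step is a number 3 percentage points higher from compound 1 to compound 3 (within the scatter). Compound 3 is estimated to give about 15%, between 3% and 30%.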

Compound 3, a percentage reported as inhibition, at one concentration (the size of the read-out at that concentration, not a potency): 17%
Estimate against measurement, compound 3: 2 percentage points below; the measured number falls inside the stated range.
By their numbers in this assay, from the lowest: compounds 1, 3 and 2 (each within the scatter of the next).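

In this assay, among these compounds, putting methoxy in place of methyl on this aromatic carbon gives a number 5 percentage points higher from compound 1 to compound 3 (within the scatter) and so offers the first direct reading of a single change. At this position, the exchange of one group for the other stays inside the usual scatter of repeated measurements, something compound 1 and compound 2 could not show, as they differ in more than one place. Nothing measured here speaks to a cause.

As far as these compounds go, whether an amine, a carboxylic acid or a longer chain at this position would give a step beyond the scatter remains open.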